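A few compounds are considered here, and "the series" means these few. Any claim that something is new, unique, unknown or untested is made for them only; others in the source may bear on it.

The measured compounds in this study are these. Compound 1 `Fc1ccc(-c2nn3ccc(Cl)cc3c2-c2ccnc(NC3CCCC3)n2)cc1` gives > 40000 nM in an ADME assay on Vero cells (Chlorocebus sabaeus) for cytotoxicity (on this read-out lower numbers stand for higher toxicity in this test and higher numbers for lower toxicity in this test), a limit of the assay. Compound 2 `Fc1ccc(-c2nn3ccc(NC4CCCC4)cc3c2-c2ccnc(NC3CCCC3)n2)cc1` gives 18000 nM in this assay. Compound 3 `COc1ccc(-c2nn3c(Cl)cc(Cl)cc3c2-c2ccnc(NC3CCCC3)n2)cc1` gives > 40000 nM in this assay, again a limit of the assay.

From compound 1 to compound 2 the change is cyclopentylamino in place of chloro on an aromatic carbon, and it made an at least 2.2-fold lower number from compound 1 to compound 2 (0.34 log units; beyond the scatter). The difference between the cores of compound 1 and compound 3 is not broken down here.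

Compound 4 `COc1ccc(-c2nn3c(NC4CCCC4)cc(Cl)cc3c2-c2ccnc(NC3CCCC3)n2)cc1` has not yet been measured. From compound 3 it differs by cyclopentylamino in place of chloro on an aromatic carbon. Among the measured compounds shown here, this is the same kind of change as the one from compound 1 to compound 2, though the place is not identical: in compound 4 the cyclopentylamino sits next to the ring nitrogen, ortho to a fused ring, meta to a chloro group and meta to a fused ring, whereas in compound 2 it is meta to a fused ring, opposite the ring nitrogen and para to a fused ring. Because compound 3 sits at the limit of > 40000 nM in this assay, at which 2 of the 3 values shown sit, the size of the step to compound 4 cannot be fixed from compound 3 alone. Compound 4 is estimated to give 20000 nM in this assay, with a likely range from 8000 nM to 45000 nM. The step of an at least 2.0-fold lower number from compound 3 to compound 4 (0.30 log units; that floor lies within the scatter) is expected because the same kind of change gave an at least 2.2-fold lower number from compound 1 to compound 2 (0.34 log units; beyond the scatter).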

Compound 4, half-maximal cytotoxic concentration: > 40000 nM
Compound 4: a limit, no number (the forecaster's own chance of this, stated with the estimate: 35%); at least 2.0-fold (0.30 log units) between middle value and limit.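

In this assay compound 4 gives > 40000 nM, a limit of the assay. No step can be read between compound 3 and compound 4, because both stand at the same limit: the limit of > 40000 nM in this assay, at which 3 of the 4 values shown sit. The compounds shown leave open whether cyclopentylamino in place of chloro changes the read-out at all on the core of compound 3, as it did on the core of compound 1.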